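A Methyl on the Core Shuts Down Activity

The source may hold more compounds than are shown below. What is called first, only, known or untested is meant among the compounds shown, and "the series" means these compounds.

Compound 2 `CS(=O)(=O)c1ccc(Nc2nccc(Nc3nc4ccccc4s3)n2)cc1` was tested in a functional assay on PC-3 cells (Homo sapiens) for antiproliferative activity, read by MTT assay, with a stated time of 48 h (on this read-out higher numbers stand for weaker inhibition and lower numbers for stronger inhibition), where compound 2 gives 1710 nM. Compound 1 `Cc1cnc(Nc2ccc(S(C)(=O)=O)cc2)nc1Nc1nc2ccccc2s1` carries one added group; in this assay compound 1 gives > 50000 nM, which is a limit of the assay rather than a number. The change is methyl in place of hydrogen on an aromatic carbon, and it brought an at least 29-fold higher number from compound 2 to compound 1 (1.46 log units; beyond the scatter), a step that ends at the limit of > 50000 nM in this assay, at which 1 of the 3 values shown sits. Compound 3 `NS(=O)(=O)c1ccc(Nc2nccc(Nc3nc4ccc(F)cc4s3)n2)cc1` gives 920 nM in this assay, close to compound 2; how the core of compound 3 differs from that of compound 2 is not broken down here. Compound 4 `Cc1cnc(Nc2ccc(S(N)(=O)=O)cc2)nc1Nc1nc2ccc(F)cc2s1` has not been measured. It differs from compound 3 by methyl in place of hydrogen on an aromatic carbon, the same change that was made from compound 2 to compound 1. Because that earlier step was an at least 29-fold higher number from compound 2 to compound 1 (1.46 log units; beyond the scatter), a similarly large loss is expected, namely a 33-fold higher number from compound 3 to compound 4 (1.51 log units; beyond the scatter). Compound 4 is therefore estimated at 30000 nM, quite possibly again reported only as a limit.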

Compound 4, half-maximal inhibitory concentration: 6980 nM
Estimate against measurement, compound 4: 4.3-fold (0.63 log units) above; the measured number lies below the stated range.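

In this assay the methyl again brings a loss, a 7.6-fold higher number from compound 3 to compound 4 (0.88 log units; beyond the scatter), so the direction of the change carries over from one core to the other, at least on these two cores. The size of the step does not carry over, as the two steps show: the same change on two cores in this assay, an at least 29-fold higher number (1.46 log units; beyond the scatter) from compound 2 to compound 1 and a 7.6-fold higher number (0.88 log units; beyond the scatter) from compound 3 to compound 4, at least 3.8-fold (0.58 log units) apart, beyond the scatter of two such steps. From the compounds shown here alone, compound 1 gives > 50000 nM, which is a limit of the assay and not a number, so the full size of the first step stays unknown.

The compounds shown leave open which of the differences between the two cores sets the size of the step. They also leave open how an ethyl group or a chlorine atom in place of the methyl would behave in this assay.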